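The source may report more compounds than this note shows. Statements on the series, on what has been measured and on what is new or still open speak of the compounds shown alone.

Measured so far in an ADME assay on a cell-free system (plasma, Mus musculus) for protein binding:
- compound 1 `CNc1nccc(N2CC[C@H](NC(=O)Nc3ccc(CN(C)C)c(C(F)(F)F)c3)C2)n1` gives 87.8%
- compound 2 `CNc1nccc(N2CC[C@H](NC(=O)Nc3ccc(Cl)c(C(F)(F)F)c3)C2)n1` gives 99.8%
- compound 3 `CNc1nccc(N2CC[C@H](NC(=O)Nc3ccc(CN4CCCC4)c(C(F)(F)F)c3)C2)n1` gives 87.2%

Compound 2 has the lowest unbound fraction of the three, with large steps on both sides (a 61-fold lower unbound fraction from compound 1 to compound 2 (1.79 log units; beyond the scatter); a 64-fold higher unbound fraction from compound 2 to compound 3 (1.81 log units; beyond the scatter)). Compound 4 `O=C(Nc1ccc(Cl)c(C(F)(F)F)c1)N[C@H]1CCN(c2ccnc(NC3CC3)n2)C1` keeps the chloro group of compound 2 and changes the other end of the molecule (cyclopropyl in place of methyl on a nitrogen on an aromatic ring), with cyclopropyl in place of methyl on a nitrogen on an aromatic ring. Among the measured compounds shown here, no measured step touches that place, and both large steps concern the chloro group. The closest in kind, pyrrolidin-1-yl in place of dimethylamino, stayed within the scatter (a 1.0-fold higher unbound fraction from compound 1 to compound 3 (0.02 log units; within the scatter)). A similarly small change is therefore expected here (a 1.3-fold lower unbound fraction from compound 2 to compound 4 (0.12 log units; within the scatter)). The estimated value for compound 4 is 99.85% (expected range 99.5% to 99.95%).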

Compound 4, plasma protein binding: 99.9%
Beside the measured number, compound 4's estimate is 1.5-fold (0.18 log units) (unbound fraction) above it; measured number inside the range.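

Among the compounds shown here, the methylamino end of the molecule is probed here for the first time, and in this assay cyclopropyl in place of methyl on that nitrogen gives a 2.0-fold lower unbound fraction from compound 2 to compound 4 (0.30 log units; within the scatter). With the chloro group kept, this position therefore tolerates the larger, ring-bearing group without a change that can be told from the scatter. Nothing available explains this result.

The compounds shown leave open whether the same change stays as small with (dimethylamino)methyl or (pyrrolidin-1-yl)methyl in place of chloro. They also leave open what a longer alkyl chain or a hydroxyethyl group would do on that nitrogen.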